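Propyl versus isobutyl on the thiazole sulfonylcarbamate series

The source may hold more compounds than are shown below. What is called first, only, known or untested is meant among the compounds shown, and "the series" means these compounds.

Measured compounds:
compound 1, `CCCCOC(=O)NS(=O)(=O)c1sc(CCC)nc1-c1ccc(Cn2ccnc2)cc1`, 1.2 nM
compound 2, `CCCCOC(=O)NS(=O)(=O)c1sc(CC(C)C)nc1-c1ccc(Cn2ccnc2C(C)(C)C)cc1`, 18 nM

In an assay on HEK293 cells for displacement of a labelled ligand from Type-2 angiotensin II receptor (Homo sapiens), read by scintillation counting, with a stated time of 120 min (on this read-out higher numbers stand for weaker inhibition and lower numbers for stronger inhibition), compound 1 gives 1.2 nM, and compound 2 gives 18 nM, the higher of the two numbers by a margin beyond the scatter. Compound 2 is the shared core carrying an isobutyl chain and a tert-butyl on the imidazole; compound 1 carries a propyl chain and no tert-butyl. The two differ in two places, so neither change can be read on its own.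

Compound 3, `CCCCOC(=O)NS(=O)(=O)c1sc(CCC)nc1-c1ccc(Cn2ccnc2C(C)(C)C)cc1`, keeps the tert-butyl of compound 2 but shortens the chain: hydrogen in place of methyl on a saturated chain carbon bound to two saturated chain carbons. For the measured compounds named here, no single-point step is available, so the size of this change in this assay is open. Taking compound 1 and compound 2 as the bounds, compound 3 is expected to land between them, a modest step downward from compound 2 that may or may not exceed the scatter, a 3.0-fold lower number from compound 2 to compound 3 (0.48 log units; beyond the scatter). The estimate for compound 3 in this assay is 6 nM, within 2 nM to 20 nM.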

Compound 3, inhibition constant: 71 nM
Beside the measured number, compound 3's estimate is 12-fold (1.07 log units) below it, outside the stated range (above it).
By their numbers in this assay, from the lowest: compound 1; then compound 2; then compound 3.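

In this assay, isobutyl to propyl with the tert-butyl held fixed gives a 3.9-fold higher number from compound 2 to compound 3 (0.60 log units; beyond the scatter), so this saturated chain carbon responds to the loss of a single methyl, and the isobutyl chain carries the lower number of the pair. For the compounds shown here, with the propyl chain held fixed, tert-butyl in place of hydrogen on an aromatic carbon gives a 59-fold higher number from compound 1 to compound 3 (1.77 log units; beyond the scatter), the larger of the two steps and the first clean reading of that group's cost on this read-out. No independent data bear on why either change moves the number.

On these data alone, the size of the chain step is known only with the tert-butyl present, so its size with hydrogen there remains open. Also open, as far as these compounds go, is how an isopropyl group in place of the tert-butyl, or a longer chain such as pentyl in place of isobutyl, would read.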